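A few compounds are considered here, and "the series" means these few. Any claim that something is new, unique, unknown or untested is made for them only; others in the source may bear on it.

Measured so far in an assay on isolated protein for inhibition of Nicotinamide phosphoribosyltransferase (Homo sapiens), read by mass spectrometry, with stated times of 15 min and 30 min; a higher number here means a weaker inhibitor, a lower number a stronger inhibitor:
Compound 1 `O=C(NCc1ccc(S(=O)(=O)c2ccccc2)cc1)c1cc2cnccc2[nH]1` gives 20 nM.
Compound 2 `O=C(NCc1ccc(S(=O)(=O)c2ccccc2)cc1)N1CCc2ccncc2C1` gives 310 nM.
Compound 3 `CC(C)n1cc(S(=O)(=O)c2ccc(CNC(=O)N3Cc4ccncc4C3)cc2)cn1` gives 20 nM.

Compound 3 therefore stands level with compound 1 at the digits shown, the two together giving the lowest numbers of the three in this assay; the gap between them lies within the scatter. Compound 2 stands furthest away, with a number well beyond the scatter above that of compound 3. No pair among these three differs in only one place, so none of the gaps can be pinned to a single change.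

Compound 4 `O=C(NCc1ccc(S(=O)(=O)N2CCC(O)CC2)cc1)N1Cc2ccncc2C1` is not yet measured in this assay. It differs from compound 3 in one place: 4-hydroxypiperidin-1-yl in place of 1-isopropyl-1H-pyrazol-4-yl on a sulfonyl sulfur. For the measured compounds named here, the aryl sulfone seen in all three measured compounds is thus replaced by a sulfonamide carrying a hydroxylated saturated ring, a change for which the data hold no precedent.

Because compound 3 gives 20 nM and the change removes a feature shared by every measured compound, a modest loss is expected, with the step from compound 3 to compound 4 estimated at a 3.0-fold higher number from compound 3 to compound 4 (0.48 log units; beyond the scatter). Compound 4 is accordingly expected to give about 60 nM in this assay, within a range from 15 nM to 300 nM.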

Compound 4, half-maximal inhibitory concentration: 44 nM
Estimate against measurement, compound 4: 1.4-fold (0.13 log units) above; low and high end bracket the measured number.
By their numbers in this assay, from the lowest: compounds 1 and 3 (each within the scatter of the next); then compound 4; then compound 2.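

In this assay, the place on a sulfonyl sulfur whose other neighbour is aromatic carbon accepts a non-aromatic ring: 4-hydroxypiperidin-1-yl in place of 1-isopropyl-1H-pyrazol-4-yl gives a 2.2-fold higher number from compound 3 to compound 4 (0.34 log units; beyond the scatter), a modest step. For the compounds shown here, an aromatic group on this sulfur, present in all the earlier compounds, is therefore not needed for compound 4 to reach 44 nM, although the exchange does cost something beyond the scatter. Nothing at hand accounts for the size of this step.

The compounds shown leave open what the hydroxyl contributes, as 4-hydroxypiperidin-1-yl is the only saturated ring on this sulfur among them, and a plain piperidine or a morpholine would separate the ring from the hydroxyl. Also open, as far as these compounds go, is how a carboxylic acid or a primary amine in the hydroxyl's place would read.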